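A few compounds are considered here, and "the series" means these few. Any claim that something is new, unique, unknown or untested is made for them only; others in the source may bear on it.

Measured so far:
compound 1, `CCc1cc(C(C)=O)c(O)cc1OCCCCC#N`: 57%
compound 2, `CCCc1cc(C(C)=O)c(O)cc1OCCCCC#N`: 37%

Both were run in an assay on isolated protein for binding affinity to leukotriene B4 receptor 1 (Homo sapiens), tested at 1 uM; on this read-out lower numbers stand for less inhibition and higher numbers for more inhibition at the one concentration tested (going by the name of the read-out). Compound 2 stands lowest of the two numbers; its nearest neighbour is compound 1, and the step of a number 20 percentage points lower from compound 1 to compound 2 (beyond the scatter) lies beyond the scatter. That step is the only one measured in the series, and it concerns the saturated chain carbon two bonds along the chain from an aromatic carbon, not the end of the chain on the aromatic oxygen.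

Compound 3, `CCCc1cc(C(C)=O)c(O)cc1OCCCCC(=O)O`, is not yet measured. It differs from compound 2 by carboxy in place of cyano on a saturated chain carbon, four bonds along the chain from an oxygen on an aromatic ring. For the measured compounds named here, no measured step bears on this change: the one step known, from compound 1 to compound 2, touches a different part of the shared core and gives no guide to exchanging cyano for carboxy. The expectation for compound 3 in this assay therefore rests only on the value of compound 2, with the direction unknown. The step of a number 8 percentage points higher from compound 2 to compound 3 (within the scatter) is thus expected to be small in the middle estimate, with a wide range to either side. Compound 3 is estimated at 45%, ranging from 15% to 80%.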

Compound 3, a percentage reported as inhibition, at one concentration (the size of the read-out at that concentration, not a potency): 0%
The estimate for compound 3 lay 45 percentage points above the measured number; the whole stated range lies above it.
By their numbers in this assay, from the lowest: compound 3; then compound 2; then compound 1.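

In this assay, for the compounds shown here, the far end of the chain on the aromatic oxygen turns out to matter: carboxy in place of cyano, on a saturated chain carbon four bonds along the chain from an oxygen on an aromatic ring, gives a number 37 percentage points lower from compound 2 to compound 3 (beyond the scatter) and is a large step, where the only earlier step, a number 20 percentage points lower from compound 1 to compound 2 (beyond the scatter) at the other chain, was modest. With cyano, compound 2 still reads 37% at the one concentration tested, whereas with carboxy compound 3 reads 0% in the same test, so the series is sensitive to what stands at this chain end and not only to the chain on the other side of the shared core. Nothing measured here accounts for this drop.

Still open, on these data alone, is whether an amide, a methyl ester or a tetrazole at this chain end would read closer to the nitrile or closer to the carboxylic acid. Also open, as far as these compounds go, are whether a shorter or longer chain carrying the carboxylic acid would recover any inhibition, and whether the same change on the core of compound 1 would give a step of similar size.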